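The source may report more compounds than this note shows. Statements on the series, on what has been measured and on what is new or still open speak of the compounds shown alone.

Compound 1 `C=CCC(N)(CO)CCc1ccc(OCCCCCCC)cc1` and compound 2 `CCCCCCCOc1ccc(CC[C@](N)(CO)CCC)cc1` share one core and differ only in one group on a saturated chain carbon, two bonds along the chain from an aromatic carbon. In a functional assay on the whole organism (spleen, spleen) with Rattus norvegicus as the target (on this read-out higher numbers stand for an effect only at larger amounts of compound and lower numbers for an effect already at smaller amounts), compound 1 gives 1.9 mg/kg. Compound 2 reaches only the limit of this assay, > 10 mg/kg, which is a boundary of the measurement and not a number. Hence an at least 5.2-fold higher number from compound 1 to compound 2 (0.72 log units; beyond the scatter) is known only as a lower bound, and compound 2 stands at the weaker end of the two values shown, at the limit (the limit of > 10 mg/kg in this assay, at which 1 of the 2 values shown sits).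

Compound 3 `CCCCCCCOc1ccc(CC[C@](N)(CO)CCO)cc1` differs from compound 2 by a single change: hydroxy in place of methyl on a saturated chain carbon, three bonds along the chain from an amine nitrogen. Among the compounds with values here, no measured step touches this kind of change: the one step available swaps a different group at a different place, so it does not tell in which direction, or how far, this assay will move. With compound 2 already at the limit, compound 3 is expected to land close to that same region, with wide uncertainty, at 10 mg/kg, between 2.5 mg/kg and 40 mg/kg. This estimate amounts to a number no higher from compound 2 to compound 3 (the limit leaves the size open), a step expected to stay within the scatter.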

Compound 3, dose for 50% inhibition: 4.2 mg/kg
Beside the measured number, compound 3's estimate is 2.4-fold (0.38 log units) above it, within the range that was stated.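

In this assay, hydroxy in place of methyl on a saturated chain carbon, three bonds along the chain from an amine nitrogen, gives an at least 2.3-fold lower number from compound 2 to compound 3 (0.37 log units; beyond the scatter). This shows that this position responds to the change, and that the response is towards an effect at smaller amounts of compound, something the earlier step could not show for this swap. The full size of the step remains unknown, since compound 2 stands at a limit and not at a number: the limit of > 10 mg/kg in this assay, at which 1 of the 3 values shown sits.

Even so, the change does not close the whole gap within this small set, as the exchange of the full group on the shared core leaves a 2.2-fold higher number from compound 1 to compound 3 (0.34 log units; beyond the scatter).

The compounds shown leave open whether hydroxy itself matters or whether other groups in the same place, such as an amine, a methoxy or a carboxylic acid, would move the number in the same direction. They also leave open what a longer chain ending in hydroxy, in place of the 2-hydroxyethyl, would do to the dose needed.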